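This account rests on a few compounds, and the source may have more. Where it says the series, first, only, none or still open, it means among the compounds named here.

Among the compounds with values here, in a functional assay on A549 cells (Homo sapiens) for antiproliferative activity, read by MTT assay, with a stated time of 48 h (a lower number here means a stronger inhibitor, a higher number a weaker inhibitor), compound 2 (`COc1ccc(C(=O)c2ccc(OC)c3c2OC(C)(C)C=C3)c(NC(=O)CO)c1`) gives 80 nM and holds the lowest number of the three compounds measured so far. In this assay compound 3 (`COc1ccc(C(=O)c2ccc(OC)c3c2C=CC(C)(C)O3)c(NC(=O)CN)c1`) gives 420 nM and compound 1 (`COc1ccc(C(=O)c2ccc(OC)c3c2C=CC(C)(C)O3)c(NC(=O)CBr)c1`) gives 2460 nM as clearly higher numbers.

The next compound, compound 4 (`CCNCC(=O)Nc1cc(OC)ccc1C(=O)c1ccc(OC)c2c1OC(C)(C)C=C2`), keeps the core of compound 2 and differs from it in one place (ethylamino in place of hydroxy on a saturated chain carbon bound to a carbonyl carbon): ethylamino in place of hydroxy on a saturated chain carbon bound to a carbonyl carbon.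

Within the data shown here, the only measured step at this kind of carbon is a 5.9-fold lower number from compound 1 to compound 3 (0.77 log units; beyond the scatter) with amino in place of bromo. It is a modest step, but it starts from bromo rather than hydroxy, and the core of compounds 1 and 3 is an isomer of the core of compounds 2 and 4, so it bears on this change only loosely. Still, an amino group on this carbon appears so far only in compound 3 with 420 nM as its value, which is higher than the number of compound 2. A moderately higher number is therefore expected in this assay rather than a lower one. The expected change is a 2.5-fold higher number from compound 2 to compound 4 (0.40 log units; beyond the scatter) in size. The estimate for compound 4 is 200 nM with an expected range from 55 nM at the lower end to 800 nM at the upper end.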

Compound 4, half-maximal inhibitory concentration: 1050 nM
For compound 4 the middle estimate is 5.3-fold (0.72 log units) below the measured one; measured number above the stated range.
By their numbers in this assay, from the lowest: compound 2; then compound 3; then compound 4; then compound 1.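

In this assay, replacing hydroxy with ethylamino on the saturated chain carbon bound to a carbonyl carbon gives a 13-fold higher number from compound 2 to compound 4 (1.12 log units; beyond the scatter), which shows that this position on the core of compound 2 is sensitive to the group it carries. Within the data shown here, the only earlier step at this kind of carbon, a 5.9-fold lower number from compound 1 to compound 3 (0.77 log units; beyond the scatter), went the other way when amino replaced bromo on the related core, so across these two steps a nitrogen-bearing group does not move the number in one fixed direction, and the outcome differs with the group that leaves and with the core. Hydroxy and ethylamino have the same count of hydrogen-bond donors and acceptors and no net charge, while ethylamino has more heavy atoms, but no measurement here explains the rise.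

The compounds shown leave open whether the rise goes with the nitrogen itself or with the ethyl group on it, a question that a plain amino group on the core of compound 2 would help to settle. Also open, from the compounds shown here alone, is how a methoxy group, a dimethylamino group or a carboxylic acid at this carbon would compare with hydroxy.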